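Carbamate to urea swap on the benzimidazole series

The source may report more compounds than this note shows. Statements on the series, on what has been measured and on what is new or still open speak of the compounds shown alone.

Measured so far in an assay on isolated protein for inhibition of Gonadotropin-releasing hormone receptor (Homo sapiens); a lower number here means a stronger inhibitor, a higher number a weaker inhibitor: compound 1 `CCn1c(SCc2cc([N+](=O)[O-])ccc2OC)nc2cc(NC(=O)NC(C)(C)C)ccc21` gives 42 nM; compound 2 `COc1ccc([N+](=O)[O-])cc1CSc1nc2cc(NC(=O)NC(C)(C)C)ccc2n1-c1ccccc1` gives 350 nM; compound 3 `COc1ccc([N+](=O)[O-])cc1CSc1nc2cc(NC(=O)OC(C)(C)C)ccc2n1C(C)C` gives 880 nM.

Compound 3 has the highest number of the three in this assay, beyond the scatter against both compound 2 and compound 1. Going by the values given here, the only single-point step measured is an 8.3-fold higher number from compound 1 to compound 2 (0.92 log units; beyond the scatter), which concerns the substituent on the aromatic nitrogen, not the carbonyl-bearing group, so it bears on the present step only by showing that this assay responds to changes of this size.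

Compound 4 `COc1ccc([N+](=O)[O-])cc1CSc1nc2cc(NC(=O)NC(C)C)ccc2n1C(C)C` differs from compound 3 by isopropylamino in place of tert-butoxy on a carbonyl carbon. Among the compounds with values here, no measured pair isolates this change; compounds 1 and 2, both ureas, carry lower numbers than carbamate compound 3, but each also differs elsewhere. Compound 4 is therefore expected to move a 4.4-fold lower number from compound 3 to compound 4 (0.64 log units; beyond the scatter), with an estimate of 200 nM and a range of 60 nM to 600 nM.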

Compound 4, half-maximal inhibitory concentration: 600 nM
Compound 4: middle estimate off by 3.0-fold (0.48 log units), on the low side; the measured number falls inside the stated range.
By their numbers in this assay, from the lowest: compound 1; then compounds 2, 4 and 3 (each within the scatter of the next, the first and the last beyond it).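

In this assay, isopropylamino in place of tert-butoxy on a carbonyl carbon gives a 1.5-fold lower number from compound 3 to compound 4 (0.17 log units; within the scatter) on an otherwise unchanged structure. Going by these compounds alone, this is the first pair to isolate the carbamate-to-urea change, and it shows no separation between the two forms beyond the scatter, even though a hydrogen-bond donor enters with isopropylamino. Nothing on hand explains this result.

As far as these compounds go, whether a methylamino or benzylamino group on this carbonyl carbon would read differently remains open. So does whether the same swap behaves alike with ethyl or phenyl on the aromatic nitrogen.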